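This account rests on a few compounds, and the source may have more. Where it says the series, first, only, none or still open, it means among the compounds named here.

Values in a functional assay on cells (Homo sapiens) for inhibition, read by MTT assay, with a stated time of 72 h (a lower number here means a stronger inhibitor, a higher number a weaker inhibitor), all three of them limits:
compound 1 `CCOC(=O)Cn1ncc2c(Nc3ccc(NS(=O)(=O)c4ccccc4)cc3)ncnc21`: > 100 ug/mL
compound 2 `CCOC(=O)Cn1ncc2c(Nc3ccc(N)cc3)ncnc21`: > 64 ug/mL
compound 3 `O=C(O)Cn1ncc2c(Nc3ccc(NS(=O)(=O)c4ccc(Br)cc4)cc3)ncnc21`: > 64 ug/mL

Compound 3 has no number in this assay: it stands at > 64 ug/mL, which is a limit. That limit is the limit of > 64 ug/mL in this assay, at which 2 of the 3 values shown sit.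

Compound 4 `CCOC(=O)Cn1ncc2c(Nc3ccc(NS(=O)(=O)c4ccc(Br)cc4)cc3)ncnc21` differs from compound 3 by ethyl in place of hydrogen on an oxygen next to a carbonyl group, which turns carboxymethyl into (ethoxycarbonyl)methyl. Among the measured compounds shown here, the only measured step is a step that the two limits leave unreadable from compound 1 to compound 2. For the measured compounds named here, it lies at another place in the structure, so no measured step covers this change and no size can be carried over from one.

The closest guide is compound 1, which carries the same (ethoxycarbonyl)methyl and stands at > 100 ug/mL, again a limit. That limit is the limit of > 100 ug/mL in this assay, at which 1 of the 3 values shown sits. On the strength of compound 1 at > 100 ug/mL, no step beyond the scatter is expected in this assay, and no direction can be given. The expected step is a step that the limit leaves unreadable from compound 3 to compound 4. Compound 4 is more likely than not to be reported only as a limit too. If a number is returned, the estimate for compound 4 is 80 ug/mL, with an expected range from 30 ug/mL to 160 ug/mL.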

Compound 4, half-maximal inhibitory concentration: > 64 ug/mL
Compound 4: no number, only a limit; the forecaster's own chance of this, stated with the estimate: 65%; the middle value is on the limit's open side.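

In this assay compound 4 gives > 64 ug/mL, which is a limit. Among the compounds shown here, compound 1, compound 2 and compound 3 also stand only as limits, so no step to compound 4 can be read. Left open is whether any of these four compounds reaches a measurable half-maximal inhibitory concentration in this assay, and how large the step from carboxymethyl to (ethoxycarbonyl)methyl is.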